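Swapping an amide cap for a sulfonamide on a pyridine

The compounds below may be only part of what the source reports. "The series", "measured", "known", "first", "only" and "open" are said of these compounds alone.

Of the compounds shown here, three have been tested in a functional assay on K562 cells (Homo sapiens) for inhibition, read by MTT assay, with a stated time of 48 h; on this read-out higher numbers stand for weaker inhibition and lower numbers for stronger inhibition. Compound 1 `CC(C)(C)C(=O)Nc1ccc(-c2ccc(C(=O)N[C@H]3CN[C@@H](C(=O)Nc4ccc(Cl)c(C(F)(F)F)c4)C3)cc2)cn1` gives 11600 nM in this assay, the second highest of the three numbers. Compound 3 `CCN(CC)C(=O)c1cncc(-c2ccc(C(=O)N[C@@H](C)C(=O)Nc3ccc(Cl)c(C(F)(F)F)c3)cc2)c1` gives 20200 nM, a number that sits within the usual scatter of compound 1. Compound 2 `C[C@H](NC(=O)c1cccc(-c2ccc(NS(C)(=O)=O)nc2)c1)C(=O)Nc1ccc(Cl)c(C(F)(F)F)c1`, which carries a methanesulfonamido group on its own ring, gives 4660 nM, a lower number than compound 1 by a margin beyond the scatter.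

Compound 4 `CS(=O)(=O)Nc1ccc(-c2ccc(C(=O)N[C@H]3CN[C@@H](C(=O)Nc4ccc(Cl)c(C(F)(F)F)c4)C3)cc2)cn1` has not yet been measured. It differs from compound 1 in one place: methylsulfonyl in place of (tert-butyl)carbonyl on a nitrogen on an aromatic ring. Among the measured compounds shown here, compound 2 shows that a methanesulfonamido group can sit in a compound with the lower number, but its linker differs from that of compound 1, so no direct step for this change is known. The step from compound 1 to compound 4 is expected to be a 1.7-fold lower number from compound 1 to compound 4 (0.22 log units; within the scatter), modest and toward lower numbers. For compound 4 the expected value in this assay is 7000 nM, with a range from 3000 nM to 18000 nM.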

Compound 4, half-maximal inhibitory concentration: 45000 nM
Compound 4: middle estimate off by 6.4-fold (0.81 log units), on the low side; the measured number lies above the stated range.
By their numbers in this assay, from the lowest: compound 2; then compounds 1 and 3 (each within the scatter of the next); then compound 4.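

In this assay, this position on the shared core responds to the cap on the nitrogen: replacing (tert-butyl)carbonyl with methylsulfonyl gives a 3.9-fold higher number from compound 1 to compound 4 (0.59 log units; beyond the scatter), a modest step but one that clears the usual scatter. Among the compounds shown here, this is the first direct reading of this change, and it runs toward weaker inhibition. A methanesulfonamido group therefore does not bring a lower number to the core of compound 1, and nothing measured here explains why.

From the compounds shown here alone, what stays open is whether the rise follows the sulfonyl group itself or the loss of the tert-butyl group: an acetyl group or a tert-butylsulfonyl group on the same nitrogen would help separate the two. A free amine at this place would show how much any cap matters here.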